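A 4-butylpiperazin-1-yl group at the chain end

The source may report more compounds than this note shows. Statements on the series, on what has been measured and on what is new or still open speak of the compounds shown alone.

In a functional assay on HCT-116 cells (Homo sapiens) for cytotoxicity, read by MTT assay, with a stated time of 72 h (a lower number here means a stronger inhibitor, a higher number a weaker inhibitor), compound 1 `O=C1c2c[n+]([O-])c3ccccc3c2C(=O)c2c1c1ccccc1n2CCCCn1ccnc1` gives 240 nM. This lies within the scatter of compound 2 `O=C1c2c[n+]([O-])c3ccccc3c2C(=O)c2c1c1ccccc1n2Cc1cn(C[C@H](O)CO)nn1` at 400 nM, while compound 3 `CC1(C)OCC(Cn2cc(Cn3c4c(c5ccccc53)C(=O)c3c[n+]([O-])c5ccccc5c3C4=O)nn2)O1` shows a lower number, 70 nM. Compound 1 therefore belongs with compound 2 as the higher pair of these three, and compound 3 stands apart from both.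

Compound 4 `CCCCN1CCN(CCCCn2c3c(c4ccccc42)C(=O)c2c[n+]([O-])c4ccccc4c2C3=O)CC1` keeps the core of compound 1 and changes one group: 4-butylpiperazin-1-yl in place of 1H-imidazol-1-yl on a saturated chain carbon, four bonds along the chain from an aromatic nitrogen. A six-membered non-aromatic ring carrying a butyl group thus takes the place of a five-membered aromatic ring, on a saturated chain carbon, four bonds along the chain from an aromatic nitrogen.

Among the measured compounds shown here, no measured pair makes this exact swap. The closest evidence comes from two other changes in the side chain. The first is a 1.7-fold higher number from compound 1 to compound 2 (0.22 log units; within the scatter), and the second is a 5.7-fold lower number from compound 2 to compound 3 (0.76 log units; beyond the scatter). In these three compounds, then, side-chain changes have ranged from no clear effect to a modest one, and neither step gives a direction for the new group. The estimated step is a 1.6-fold lower number from compound 1 to compound 4 (0.20 log units; within the scatter), so nothing beyond the scatter is expected. For compound 4 the estimate is 150 nM, with an expected range from 50 nM to 450 nM.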

Compound 4, half-maximal inhibitory concentration: 1920 nM
Estimate against measurement, compound 4: 13-fold (1.11 log units) below; the whole stated range lies below it.
By their numbers in this assay, from the lowest: compound 3; then compounds 1 and 2 (each within the scatter of the next); then compound 4.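

Among the compounds shown here, at this place, on a saturated chain carbon, four bonds along the chain from an aromatic nitrogen, putting 4-butylpiperazin-1-yl in place of 1H-imidazol-1-yl gives an 8.0-fold higher number from compound 1 to compound 4 (0.90 log units; beyond the scatter) in this assay; this shows that the group at the chain end can weaken this cytotoxic effect, whereas the only earlier step beyond the scatter lowered the number. The swap brings in a group with more heavy atoms and replaces a five-membered aromatic ring with a six-membered non-aromatic one, while the counts of hydrogen-bond donors and acceptors and the net charge stay the same, so those counts do not separate the two groups. Nothing measured here explains the rise in the number.

From the compounds shown here alone, the change alters the ring and adds the butyl group in a single step, so it remains open which of these matters. A plain piperazin-1-yl group or a 4-methylpiperazin-1-yl group at the same place would help to tell the ring's contribution from that of the butyl chain.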